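Naphthyloxyacetyl hydrazone series: lipophilicity, step to compound 4

The compounds below may be only part of what the source reports. "The series", "measured", "known", "first", "only" and "open" are said of these compounds alone.

Three compounds share one core and differ only in the aryl group on the carbon with a double bond to nitrogen. Compound 1 `O=C(COc1cccc2ccccc12)N/N=C/c1ccccc1[N+](=O)[O-]` gives 3.97 in a physicochemical assay for lipophilicity, measured as octanol-water partition; a lower number here means a more polar compound, a higher number a more lipophilic compound; compound 2 `COc1ccc(/C=N/NC(=O)COc2cccc3ccccc23)cc1O` gives 3.48; compound 3 `O=C(COc1cccc2ccccc12)N/N=C/c1ccccc1O` gives 3.73. Compound 3 stands second highest of the three, with compound 1 nearest and compound 2 furthest, both within the scatter. Among the compounds with values here, the single measured step, a number 0.24 log units lower from compound 1 to compound 3 (within the scatter), is itself within the scatter.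

Compound 4 `COc1ccc(/C=N/NC(=O)COc2cccc3ccccc23)cc1` is not yet measured. It differs from compound 3 as follows: 4-methoxyphenyl in place of 2-hydroxyphenyl on a carbon with a double bond to nitrogen. Within the data shown here, no measured step swaps these two groups directly, so the only guide is that compound 2, which carries both a hydroxy and a methoxy, sits at 3.48, and that the one swap on this aryl group seen so far, from nitro to hydroxy, stayed within the scatter. The step from compound 3 to compound 4 is therefore expected to be small, a number 0.12 log units higher from compound 3 to compound 4 (within the scatter), if anything slightly upward. Compound 4 is estimated at 3.85, with a range from 3.45 to 4.25.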

Compound 4, partition coefficient: 3.77
Compound 4: middle estimate off by 0.08 log units, on the high side; measured number inside the range.
By their numbers in this assay, from the lowest: compounds 2, 3, 4 and 1 (each within the scatter of the next, the first and the last beyond it).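

In this assay, 4-methoxyphenyl in place of 2-hydroxyphenyl on a carbon with a double bond to nitrogen gives a number 0.04 log units higher from compound 3 to compound 4 (within the scatter), even though the leaving group has 1 hydrogen-bond donor and the entering group has 0 hydrogen-bond donors. Hydrogen in place of hydroxy on an aromatic carbon gives a number 0.29 log units higher from compound 2 to compound 4 (within the scatter), so this change too stays within the scatter, and the three single-place steps now available in the series all do. Nothing at hand bears on the reason for these small steps.

Open, going by these compounds, is whether any group at this place gives a step beyond the scatter. An amine or a carboxylic acid on the aromatic ring, both absent from the compounds shown, would test this.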